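The source may report more compounds than this note shows. Statements on the series, on what has been measured and on what is new or still open speak of the compounds shown alone.

Measured so far in an assay on microsomes from liver for inhibition of sterol O-acyltransferase 1 (Rattus norvegicus); a higher number here means a weaker inhibitor, a lower number a stronger inhibitor:

compound 1, `C[C@@]1(O)CC(=O)OC(CSc2nc(-c3ccccc3)c(-c3ccccc3)[nH]2)C1`: 170 nM
compound 2, `Cc1cccc(-c2nc(SC[C@H]3C[C@@](C)(O)CC(=O)O3)[nH]c2-c2cccc(C)c2)c1.Cc1cccc(-c2nc(SC[C@H]3C[C@](C)(O)CC(=O)O3)[nH]c2-c2cccc(C)c2)c1`: 64 nM
compound 3, `CC1=CC(=O)OC(CSc2nc(-c3cccc(Cl)c3)c(-c3cccc(Cl)c3)[nH]2)C1`: 440 nM

Compound 1 gives the second highest of the three numbers. Compound 3 lies closest to it, with a number beyond the scatter higher; compound 2 is the furthest, with a number beyond the scatter lower. Both neighbours carry different aryl substitution as well as a different saturated ring, so neither pair forms a single-point step, and only the bare values can be compared.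

Compound 4, `CO[C@H]1C[C@H](O)C[C@@H](CSc2nc(-c3ccccc3)c(-c3ccccc3)[nH]2)O1`, differs from compound 1 in the ring attached through the sulfur-bound chain carbon: a group of 9 heavy atoms (6 carbon, 3 oxygen; one six-membered non-aromatic ring with 1 hetero atom) in place of a group of 9 heavy atoms (6 carbon, 3 oxygen; one six-membered non-aromatic ring with 1 hetero atom), on a saturated chain carbon bound to a sulfur. The ring keeps its size, its single ring oxygen and its donor and acceptor counts, but the double bond outside aromatic rings is gone and two further stereocentres appear. Among the measured compounds shown here, no measured pair in this set isolates such a change, so the direction cannot be read from the data. The expectation is for a small shift in this assay , at most around the edge of the scatter and if anything towards a higher number, giving a step of a 1.5-fold higher number from compound 1 to compound 4 (0.17 log units; within the scatter) from compound 1 to compound 4. The estimate for compound 4 is 250 nM, within a range from 80 nM to 800 nM.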

Compound 4, half-maximal inhibitory concentration: 90 nM
Beside the measured number, compound 4's estimate is 2.8-fold (0.44 log units) above it; measured number inside the range.
By their numbers in this assay, from the lowest: compounds 2, 4 and 1 (each within the scatter of the next, the first and the last beyond it); then compound 3.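

This gives the series its first single-place reading at the saturated chain carbon bound to the sulfur: in this assay the ring exchange on the core of compound 1 gives a 1.9-fold lower number from compound 1 to compound 4 (0.28 log units; within the scatter). The ring at this place can therefore lose its double bond outside aromatic rings and carry three defined stereocentres instead of one, with no step beyond the scatter. No measurement shown explains this result, and nothing here assigns it to a particular feature of either ring.

The contributions of the lost double bond and of the added stereocentres remain unseparated, as each stereocentre appears in only one arrangement. As far as these compounds go, it also remains open how this position responds to a group of a different kind, such as an open chain ending in a carboxylic acid or an amine in place of the ring.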